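The source may hold more compounds than are shown below. What is called first, only, known or untested is meant among the compounds shown, and "the series" means these compounds.

Measured so far:
- compound 1, `COc1ccccc1NC(=O)CSc1nnc(-c2ccoc2C)n1Cc1ccco1`: 501 nM
- compound 2, `COc1ccc(NC(=O)CSc2nnc(-c3ccoc3C)n2Cc2ccco2)cc1`: 200 nM
- compound 3, `CC(=O)c1cccc(NC(=O)CSc2nnc(-c3ccoc3C)n2Cc2ccco2)c1`: 316 nM

All three share a core and differ only in the group on the amide-type nitrogen. In a functional assay on CHO cells for antagonist activity at Orexin receptor type 2 (Homo sapiens), read by FLIPR and calcium flux (a higher number here means a weaker inhibitor, a lower number a stronger inhibitor), compound 3 gives 316 nM; the step of a 1.6-fold lower number from compound 1 to compound 3 (0.20 log units; within the scatter) and the step of a 1.6-fold higher number from compound 2 to compound 3 (0.20 log units; within the scatter) both stay within the scatter, so compound 3 is not separated from either neighbour. Within the data shown here, the only step beyond the scatter is a 2.5-fold lower number from compound 1 to compound 2 (0.40 log units; beyond the scatter), a swap of one substituted phenyl for another.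

Compound 4, `Cc1occc1-c1nnc(SCC(=O)NN2CCc3ccccc32)n1Cc1ccco1`, is not yet measured. Relative to compound 3 the change is 2,3-dihydro-1H-indol-1-yl in place of 3-acetylphenyl on an amide-type nitrogen. Among the measured compounds shown here, none of the measured steps exchanges the aromatic ring for a saturated ring-fused nitrogen group; the phenyl-to-phenyl steps only show that the series tolerates variation here within a narrow band. The expectation for compound 4 in this assay is therefore weak, leaning toward a somewhat higher number, estimated as a 2.5-fold higher number from compound 3 to compound 4 (0.40 log units; beyond the scatter). Compound 4 is expected at 800 nM, with a range of 150 nM to 4000 nM.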

Compound 4, inhibition constant: 1000 nM
Compound 4: middle estimate off by 1.3-fold (0.10 log units), on the low side, within the range that was stated.
By their numbers in this assay, from the lowest: compounds 2, 3, 1 and 4 (each within the scatter of the next, the first and the last beyond it).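

In this assay, a group other than a substituted phenyl on the amide-type nitrogen gives a measurable loss against two of the three phenyl compounds: a 3.2-fold higher number from compound 3 to compound 4 (0.50 log units; beyond the scatter) and a 5.0-fold higher number from compound 2 to compound 4 (0.70 log units; beyond the scatter). The third comparison does not show this, as a 2.0-fold higher number from compound 1 to compound 4 (0.30 log units; within the scatter) leaves compound 4 unseparated from the 2-methoxyphenyl compound, so the 2,3-dihydro-1H-indol-1-yl group extends the range of values at this position without clearly falling outside it. No measurement is available to explain these differences.

The compounds shown do not separate the contribution of the ring nitrogen in the 2,3-dihydro-1H-indol-1-yl group from that of its fused five-membered ring. A piperidin-1-yl or dimethylamino group on the same amide-type nitrogen would bear on that question.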